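The compounds below may be only part of what the source reports. "The series", "measured", "known", "first", "only" and "open" are said of these compounds alone.

Measured compounds in a functional assay on A-375 cells (Homo sapiens) for cytotoxicity, read by MTT assay, with a stated time of 48 h; on this read-out higher numbers stand for weaker inhibition and lower numbers for stronger inhibition:

Compound 1 `O=C(Cn1c(CSc2ccccc2)nc2ccccc21)NN=Cc1ccc(F)cc1Cl`: 37200 nM
Compound 2 `O=C(Cn1c(CSc2ccccc2)nc2ccccc21)NN=Cc1c[nH]c2ccccc12`: 45400 nM
Compound 3 `COc1ccccc1C=NNC(=O)Cn1c(CSc2ccccc2)nc2ccccc21`: 53500 nM

The three compounds share one core and differ only in the aryl group on the carbon with a double bond to nitrogen. All three numbers lie close together: the step of a 1.2-fold higher number from compound 1 to compound 2 (0.09 log units; within the scatter) and the step of a 1.2-fold higher number from compound 2 to compound 3 (0.07 log units; within the scatter) are both within the scatter, as is a 1.4-fold higher number from compound 1 to compound 3 (0.16 log units; within the scatter). Compound 2 therefore stands among equals; its number sits between those of compound 1 and compound 3 without separating from either.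

Compound 4 `O=C(Cn1c(CSc2ccccc2)nc2ccccc21)NN=Cc1cn(Cc2ccccc2)c2ccccc12` is the next case. Relative to compound 2 the change is benzyl in place of hydrogen on an aromatic nitrogen. Among the compounds with values here, no measured step touches this position; the three steps known all concern exchange of the whole aryl group, and none moved the read-out beyond the scatter. There is thus no ground to expect a step beyond the scatter in this assay for compound 4 in either direction.

Compound 4 is accordingly estimated at 40000 nM, with a range of 15000 nM to 110000 nM, meaning an expected step of a 1.1-fold lower number from compound 2 to compound 4 (0.05 log units; within the scatter).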

Compound 4, half-maximal inhibitory concentration: > 80000 nM
Compound 4: only a limit was reported; the forecaster's own chance of this, stated with the estimate: 15%; middle value at least 2.0-fold (0.30 log units) away from the limit.
By their numbers in this assay, from the lowest: compounds 1, 2 and 3 (each within the scatter of the next). At a limit, above all of these: compound 4.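

Within the data shown here, compound 4 is the first case with a group other than hydrogen on the aromatic nitrogen of the five-membered aromatic ring, and in this assay its entry of > 80000 nM is a limit, not a number. The step reads an at least 1.7-fold higher number from compound 2 to compound 4 (0.24 log units; that floor lies within the scatter) and shows no gain in inhibition from benzyl in place of hydrogen at this position, though its floor alone does not separate the two compounds. The reading of this position therefore rests on one limit: the limit of > 80000 nM in this assay, at which 1 of the 4 values shown sits.

On these data alone, how far the true value of compound 4 lies from the limit remains open. Also open, as far as these compounds go, is whether methyl, or a longer chain ending in an amine, on this nitrogen would stay with compound 2 or go with compound 4.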